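This account rests on a few compounds, and the source may have more. Where it says the series, first, only, none or still open, it means among the compounds named here.

Measured compounds:
compound 1, `CCOC(=O)C1=Cc2ccccc2OC1(OCc1cc(-c2ccc3ccccc3c2)no1)C(F)(F)F`, 71800 nM
compound 2, `Cc1ccc(-c2cc(COC3(C(F)(F)F)Oc4ccccc4C=C3C(=O)O)on2)cc1`, 41400 nM
compound 3, `O=C(O)C1=Cc2ccccc2OC1(OCc1cc(-c2ccc([N+](=O)[O-])cc2)no1)C(F)(F)F`, 100000 nM

In a functional assay on DU-145 cells (Homo sapiens) for inhibition, read by MTT assay, with a stated time of 24 h (on this read-out higher numbers stand for weaker inhibition and lower numbers for stronger inhibition), compound 3 gives the highest of the three numbers. Its nearest neighbour is compound 1, whose value of 71800 nM lies within the scatter of it; furthest off is compound 2, and the step of a 2.4-fold higher number from compound 2 to compound 3 (0.38 log units; beyond the scatter) is beyond the scatter, coming with nitro in place of methyl on an aromatic carbon.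

Compound 4, `O=C(O)C1=Cc2ccccc2OC1(OCc1cc(-c2ccc3ccccc3c2)no1)C(F)(F)F`, has not yet been measured in this assay. It differs from compound 3 in one place: naphthalen-2-yl in place of 4-nitrophenyl on an aromatic carbon.

Among the measured compounds shown here, the only step that bears on this change is a 2.4-fold higher number from compound 2 to compound 3 (0.38 log units; beyond the scatter), which shows that replacing a methyl with a nitro group at this position raised the number modestly. Going from compound 3 to compound 4 removes that nitro group again and brings in naphthalen-2-yl, a group also carried by compound 1, which gives 71800 nM with an ethyl ester where compound 4 carries a carboxylic acid. For the measured compounds named here, no step between compound 1 and compound 4 has been measured, so only their values can be set side by side.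

On this basis compound 4 is expected to show a lower number than compound 3, by about a 2.0-fold lower number from compound 3 to compound 4 (0.30 log units; within the scatter). The estimate for compound 4 in this assay is 50000 nM, with a range from 20000 nM to 120000 nM.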

Compound 4, half-maximal inhibitory concentration: 141000 nM
Beside the measured number, compound 4's estimate is 2.8-fold (0.45 log units) below it; measured number above the stated range.
By their numbers in this assay, from the lowest: compounds 2, 1, 3 and 4 (each within the scatter of the next, the first and the last beyond it).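

In this assay, putting naphthalen-2-yl in place of 4-nitrophenyl on the aromatic carbon of the five-membered ring does not separate the two acids: a 1.4-fold higher number from compound 3 to compound 4 (0.15 log units; within the scatter). Set against 4-methylphenyl, the same group does separate, with a 3.4-fold higher number from compound 2 to compound 4 (0.53 log units; beyond the scatter), so among the three acids shown, the one carrying 4-methylphenyl stands beyond the scatter of the other two, though all of the numbers remain high. With naphthalen-2-yl held fixed, the change from ethyl ester to carboxylic acid can now be read directly, and a 2.0-fold higher number from compound 1 to compound 4 (0.29 log units; within the scatter) does not tell the two apart. Nothing measured here offers a reason for any of these steps.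

The compounds shown leave open whether an aminophenyl or methoxyphenyl group at this place would fall with 4-methylphenyl or with the other two groups. They also leave open whether ester and acid would still match when another group occupies this place, and how a primary amide in place of the carboxylic acid would read.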